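This account rests on a few compounds, and the source may have more. Where it says the series, first, only, none or still open, it means among the compounds named here.

Series notes. Among the measured compounds shown here, compound 1 `CC1=NN(C(=O)c2ccc(C)cc2)C(c2cc(Br)ccc2O)C1` gives 41200 nM in a functional assay on PC-3 cells (Homo sapiens) for cytotoxicity, read by MTT assay, with a stated time of 48 h (a lower number here means a stronger inhibitor, a higher number a weaker inhibitor), and compound 2 `CC1=NN(C(=O)c2ccc(C)cc2)C(c2cc(Br)cc(Br)c2O)C1` gives 41200 nM; the one step available, no change at the digits printed from compound 1 to compound 2 (within the scatter), shows the bromo in place of hydrogen on an aromatic carbon left the number where it was. Compound 3 `Cc1ccc(C(=O)N2N=C(c3cc4ccccc4oc3=O)CC2c2ccccc2)cc1` gives 13200 nM and stands lowest of the three numbers, with both other compounds lying beyond the scatter above it.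

Compound 4 `NC(=O)C1CCN(CC(=O)N2N=C(c3cc4ccccc4oc3=O)CC2c2ccccc2)CC1` carries the change ((4-carbamoylpiperidin-1-yl)methyl in place of 4-methylphenyl on a carbonyl carbon). For the measured compounds named here, no measured step bears on this exchange: the only step seen concerns a bromo on an aromatic carbon, not a replacement of the whole group on the carbonyl carbon, so nothing says whether the carbamoylpiperidinylmethyl will move the number. With no guidance either way, the expected step of a 1.1-fold higher number from compound 3 to compound 4 (0.06 log units; within the scatter) is taken as none beyond the scatter, with a wide range to cover the missing information. Compound 4 is therefore estimated at 15000 nM, between 4000 nM and 55000 nM.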

Compound 4, half-maximal inhibitory concentration: 8310 nM
The estimate for compound 4 lay 1.8-fold (0.26 log units) above the measured number, and the stated range covers the measured number.
By their numbers in this assay, from the lowest: compounds 4 and 3 (each within the scatter of the next); then compounds 1 and 2 (each within the scatter of the next).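

On the carbonyl carbon whose other neighbour is the amide-type nitrogen in a ring, this assay shows a 1.6-fold lower number from compound 3 to compound 4 (0.20 log units; within the scatter) for (4-carbamoylpiperidin-1-yl)methyl in place of 4-methylphenyl, and this is the series' only reading at this position. The exchange removes the six-membered aromatic ring of carbon only and brings in a six-membered non-aromatic ring with 1 hetero atom, 1 hydrogen-bond donor and 2 hydrogen-bond acceptors, yet the step stays within the scatter. So this position accepts a very different group without a change that can be told from the scatter, and nothing measured on these compounds offers an explanation for that.

Open, going by these compounds, is whether a carboxylic acid in place of the carbamoyl group, or a longer chain in place of the methyl, would hold the number. Also open, on these data alone, is whether (4-carbamoylpiperidin-1-yl)methyl would behave the same way on the core of compound 1.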